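The source may hold more compounds than are shown below. What is called first, only, known or untested is meant among the compounds shown, and "the series" means these compounds.

In a functional assay on HepG2 cells (Homo sapiens) for antiproliferative activity, read by MTT assay, with a stated time of 72 h (on this read-out higher numbers stand for weaker inhibition and lower numbers for stronger inhibition), compound 1 `CCOC(=O)c1csc2nc(CN3CCN(Cc4ccccc4)CC3)c(-c3ccc(C)cc3)n12` gives 88200 nM and compound 2 `CCOC(=O)c1csc2nc(CN3CCN(C)CC3)c(-c3ccc(OC)cc3)n12` gives 68400 nM. Going by the values given here, these two values lie within the usual scatter of each other, so compound 2 stands level with the only other compound measured so far. Compound 3 `CCOC(=O)c1csc2nc(CN3CCN(Cc4ccccc4)CC3)c(-c3ccc(OC)cc3)n12` is compound 2 with a single change: phenyl in place of hydrogen on a saturated chain carbon bound to an amine nitrogen in a ring. This places phenyl in place of hydrogen on a saturated chain carbon bound to an amine nitrogen in a ring, which turns methyl into benzyl. Among the compounds with values here, no measured pair of compounds shows this change on its own, so its size in this assay cannot be read directly. With only compound 2 at 68400 nM and compound 1 at 88200 nM to go on, no step beyond the scatter is expected. The estimated step of a 1.1-fold higher number from compound 2 to compound 3 (0.04 log units; within the scatter) is therefore small. Compound 3 is expected at 75000 nM, with an estimated range of 40000 nM to 130000 nM.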

Compound 3, half-maximal inhibitory concentration: 26400 nM
Compound 3: middle estimate off by 2.8-fold (0.45 log units), on the high side, and the stated range ends above it.
By their numbers in this assay, from the lowest: compound 3; then compounds 2 and 1 (each within the scatter of the next).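

In this assay, the change from methyl to benzyl gives a 2.6-fold lower number from compound 2 to compound 3 (0.41 log units; beyond the scatter), the first size seen for this change at this position. With benzyl kept in place, methoxy in place of methyl on an aromatic carbon gives a 3.3-fold lower number from compound 1 to compound 3 (0.52 log units; beyond the scatter), so compound 3, which carries both benzyl and methoxy, has a lower number than either compound that differs from it in one of these places. Nothing available here gives a reason for either step.

The compounds shown leave open whether the benzyl step would have the same size with methyl rather than methoxy on the aromatic carbon. They also leave open how a longer chain, such as phenethyl, in place of benzyl, or a chlorine atom in place of methoxy, would compare.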